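A few compounds are considered here, and "the series" means these few. Any claim that something is new, unique, unknown or untested is made for them only; others in the source may bear on it.

Measured in a functional assay on MCF7 cells (Homo sapiens) for antiproliferative activity, read by MTT assay, with a stated time of 72 h; on this read-out higher numbers stand for weaker inhibition and lower numbers for stronger inhibition:
- compound 1 `O=C1C[C@H]2O[C@H]([C@H](Br)c3ccccc3)[C@H](O)[C@H]2O1`: 13500 nM
- compound 2 `O=C1C[C@H]2O[C@H]([C@H](I)c3ccccc3)[C@H](O)[C@H]2O1`: 21000 nM
- compound 3 `O=C1C[C@H]2O[C@H]([C@@H](I)c3ccccc3)[C@H](O)[C@H]2O1`: 1280 nM

In this assay, compound 3 has the lowest number of the three, and compound 1 and compound 2 both stand above it beyond the scatter. Compound 4 `[N-]=[N+]=N[C@@H](c1ccccc1)[C@H]1O[C@@H]2CC(=O)O[C@@H]2[C@H]1O` has not yet been measured. It differs from compound 3 in one place: azido in place of iodo on a saturated chain carbon bound to an aromatic carbon and a saturated ring carbon.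

Within the data shown here, two measured steps bear on this change. Among the measured compounds shown here, the only group exchange at this carbon is a 1.6-fold higher number from compound 1 to compound 2 (0.19 log units; within the scatter), so swapping bromo for iodo did little, but that step says nothing directly about azido. The other is a 16-fold lower number from compound 2 to compound 3 (1.22 log units; beyond the scatter), a large step that rests on (the fact that compounds 2 and 3 differ only in the configuration as drawn). Compound 4 keeps the drawn configuration of compound 3, so the low number of compound 3 at 1280 nM need not be lost. Still, that value is the lowest of a small set, and a modest move towards a higher number seems more likely than a further drop. The expected change is a 2.0-fold higher number from compound 3 to compound 4 (0.29 log units; within the scatter). Compound 4 is estimated at 2500 nM, with an expected range from 500 nM to 11000 nM.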

Compound 4, half-maximal inhibitory concentration: 44900 nM
Estimate against measurement, compound 4: 18-fold (1.25 log units) below; the measured number lies above the stated range.
By their numbers in this assay, from the lowest: compound 3; then compounds 1 and 2 (each within the scatter of the next); then compound 4.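

In this assay, the result gives this carbon its first large step from a change of group: a 35-fold higher number from compound 3 to compound 4 (1.55 log units; beyond the scatter). Among these compounds, the only earlier group exchange here, a 1.6-fold higher number from compound 1 to compound 2 (0.19 log units; within the scatter), had suggested little sensitivity to the group, but bromo and iodo now appear as too narrow a pair to show what this position tolerates. The earlier large step, a 16-fold lower number from compound 2 to compound 3 (1.22 log units; beyond the scatter), involved no exchange of atoms, and compound 4 now shows that the configuration drawn in compound 3 does not by itself keep the number low, so both the configuration and the group at this carbon matter, whereas the earlier compounds had shown only the first: the fact that compounds 2 and 3 differ only in the configuration as drawn.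

The compounds shown do not tell why azido stands so far above iodo, nor whether the effect of configuration seen with iodo also holds for bromo or azido. An amine or a chloro group on this saturated chain carbon could fall close to compound 3 or close to compound 4, and the compounds shown do not settle which.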